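Para substituent swap on the benzylamine arm: phenyl replaces trifluoromethyl

The source may hold more compounds than are shown below. What is called first, only, known or untested is meant among the compounds shown, and "the series" means these compounds.

Three compounds share a core in which a bis(trifluoromethyl)benzenesulfonamide is joined through a three-carbon chain to a benzylamine. Compound 1 `O=S(=O)(NCCCNCc1ccc(Cl)cc1)c1cc(C(F)(F)F)cc(C(F)(F)F)c1` carries a chloro on the benzyl ring; in a toxicity assay on MCF-10A cells (Homo sapiens) for inhibition, read by MTT assay, with a stated time of 72 h (a higher number here means a weaker inhibitor of growth, a lower number a stronger inhibitor of growth), compound 1 gives 2300 nM. Compound 2 `CC(C)(C)c1ccc(CNCCCNS(=O)(=O)c2cc(C(F)(F)F)cc(C(F)(F)F)c2)cc1` carries a tert-butyl there and in this assay compound 2 gives 3200 nM. Compound 3 `O=S(=O)(NCCCNCc1ccc(C(F)(F)F)cc1)c1cc(C(F)(F)F)cc(C(F)(F)F)c1` carries a trifluoromethyl and in this assay compound 3 gives 3300 nM. Compound 3 has the highest of the three numbers, yet every gap to it falls within the scatter: a 1.4-fold higher number from compound 1 to compound 3 (0.16 log units; within the scatter) and a 1.0-fold higher number from compound 2 to compound 3 (0.01 log units; within the scatter), as does a 1.4-fold higher number from compound 1 to compound 2 (0.14 log units; within the scatter).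

Compound 4 `O=S(=O)(NCCCNCc1ccc(-c2ccccc2)cc1)c1cc(C(F)(F)F)cc(C(F)(F)F)c1` is not yet measured. It differs from compound 3 in one place: phenyl in place of trifluoromethyl on an aromatic carbon. The three measured steps all change the group at this same position and none moves the number beyond the scatter, so the position appears tolerant across chloro, tert-butyl and trifluoromethyl. Phenyl is larger than any of those, but no measured step speaks to so large a group. The step of a 1.1-fold lower number from compound 3 to compound 4 (0.04 log units; within the scatter) is therefore expected to stay within the scatter. The estimate for compound 4 in this assay is 3000 nM, expected to fall between 1200 nM and 8000 nM.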

Compound 4, concentration for 50% growth inhibition: 2800 nM
Beside the measured number, compound 4's estimate is 1.1-fold (0.03 log units) above it; the range from low to high includes it.
By their numbers in this assay, from the lowest: compounds 1, 4, 2 and 3 (each within the scatter of the next).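

In this assay, within the data shown here, phenyl is the first group at this place to bring a ring, one six-membered aromatic ring of carbon only, and its 6 heavy atoms replace the 4 of trifluoromethyl, yet the result is a 1.2-fold lower number from compound 3 to compound 4 (0.07 log units; within the scatter) against trifluoromethyl, a 1.1-fold lower number from compound 2 to compound 4 (0.06 log units; within the scatter) against tert-butyl and a 1.2-fold higher number from compound 1 to compound 4 (0.09 log units; within the scatter) against chloro, each step within the scatter. Among these compounds, the tolerance that the earlier compounds showed among chloro, tert-butyl and trifluoromethyl therefore also covers an aromatic ring on this aromatic carbon, para to a large group, so none of the four compounds goes against it and the four groups cannot be told apart by this read-out. No accompanying measurement offers an explanation of why the number stays put when this group changes.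

The compounds shown leave open whether an amine or a carboxylic acid on this aromatic carbon would hold the number as these four groups do. They also leave open whether the number would stay the same if a longer chain replaced the three-carbon chain of the shared core, or if a second phenyl ring were extended further by a morpholine.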